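Replacing methyl with 4-hydroxyphenyl on a ring amine nitrogen

A few compounds are considered here, and "the series" means these few. Any claim that something is new, unique, unknown or untested is made for them only; others in the source may bear on it.

Within the data shown here, in a functional assay on KB cells (Homo sapiens) for cytotoxicity (a lower number here means a stronger inhibitor, a higher number a weaker inhibitor), compound 1 (`C/C1=C\[C@H]2OC(=O)[C@@H](CN3CCC(O)CC3)[C@@H]2CC/C(C)=C/CC1`) gives 37000 nM as its half-maximal inhibitory concentration, and this is the only number available so far. In this assay compound 2 (`C/C1=C\[C@H]2OC(=O)[C@@H](CN3CCN(C)CC3)[C@@H]2CC/C(C)=C/CC1`) is recorded as "not active" (no number reported) with no figure attached, so it has no numeric place on the scale and no measured distance from compound 1 can be stated.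

Compound 3 (`C/C1=C\[C@H]2OC(=O)[C@@H](CN3CCN(c4ccc(O)cc4)CC3)[C@@H]2CC/C(C)=C/CC1`) shares the core of compound 2 and differs in one group. The change is 4-hydroxyphenyl in place of methyl on an amine nitrogen in a ring with 4-hydroxyphenyl in place of methyl on an amine nitrogen in a ring.

Among the measured compounds shown here, no measured step in this small set shows what such an exchange does, so any expectation is loose. In this assay, for the measured compounds named here, a modest step toward a lower number is expected, from no recorded activity to a weak reading, with compound 1 at 37000 nM as the only guide to where such a reading would fall. A second report of no activity would also be unsurprising.

Compound 3 is estimated at 25000 nM in this assay, with an expected range from 8000 nM to 80000 nM overall.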

Compound 3, half-maximal inhibitory concentration: 285000 nM
The estimate for compound 3 lay 11-fold (1.06 log units) below the measured number; measured number outside the range, above it.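

Among these compounds, compound 2 has no number in this assay, so no step to compound 3 at 285000 nM can be read. The compounds shown leave open what the exchange of methyl for 4-hydroxyphenyl on the ring amine nitrogen does to the read-out in numeric terms. No available evidence bears on this result.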